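Methoxyphenyl for difluorophenyl on the shared core

The compounds below may be only part of what the source reports. "The series", "measured", "known", "first", "only" and "open" are said of these compounds alone.

Compound 1 `CCOC(=O)C1=Cc2ccccc2OC1(OCc1cc(-c2ccc(F)cc2F)no1)C(F)(F)F` is one of three members of the series with a result in a functional assay on MCF7 cells (Homo sapiens) for inhibition, read by MTT assay, with a stated time of 24 h; a higher number here means a weaker inhibitor, a lower number a stronger inhibitor. In this assay compound 1 gives > 150000 nM, which is a limit of the assay and not a number. Compound 2 `CCOC(=O)C1=Cc2ccccc2OC1(OCc1cn(-c2cccc(OC)c2)nn1)C(F)(F)F` stands the same way: in this assay compound 2 gives > 150000 nM, again a limit. For the measured compounds named here, compound 3 `CCOC(=O)C1=Cc2ccccc2OC1(OCc1cn(CC(=O)Nc2ccc(OC)cc2)nn1)C(F)(F)F` is the one member with a number; in this assay compound 3 gives 28100 nM. Going by the values given here, the only measured single-point step is an at least 5.3-fold lower number from compound 2 to compound 3 (0.72 log units; beyond the scatter), a change on an aromatic nitrogen. Compound 1 thus sits with compound 2 at the limit, and the limit of > 150000 nM in this assay, at which 2 of the 3 values shown sit, shows how little the present numbers resolve.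

Compound 4 `CCOC(=O)C1=Cc2ccccc2OC1(OCc1cc(-c2ccc(OC)cc2)no1)C(F)(F)F` differs from compound 1 by 4-methoxyphenyl in place of 2,4-difluorophenyl on an aromatic carbon. Among the compounds with values here, no measured step alters a group at this place; the step from compound 2 to compound 3 concerns a different attachment and a different kind of group, so it bears only loosely here. Nothing shown separates a fluorinated from a methoxylated aryl at this position. The expectation for compound 4 is therefore a result near the limit, the step of a number no higher from compound 1 to compound 4 (the limit leaves the size open) being estimated as none beyond the scatter. Compound 4 is expected at 150000 nM, within 40000 nM to 600000 nM, with a fair chance that only a limit is returned.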

Compound 4, half-maximal inhibitory concentration: > 150000 nM
Compound 4: only a limit was reported; the forecaster's own chance of this, stated with the estimate: 65%; the middle value sits exactly at the limit.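

No new step can be read: compound 1 and compound 4 both stand only as limits in this assay, so the change from 2,4-difluorophenyl to 4-methoxyphenyl cannot be sized. Still open is whether these two groups differ at all at this place on the shared core, with most of the series resting on one limit: the limit of > 150000 nM in this assay, at which 3 of the 4 values shown sit.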